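The compounds below may be only part of what the source reports. "The series", "measured", "known", "first", "only" and "open" are said of these compounds alone.

Compound 1, `CC(C)N(Cc1cccc(OCCCCCC(=O)O)c1)C(=O)c1ccc(-c2cccc(-c3ccccc3)c2)cc1`: in an ADME assay on HepG2 cells (Homo sapiens) for cytotoxicity, read by CellTiter-Glo and resazurin assay, with a stated time of 72 h (on this read-out lower numbers stand for an effect already at smaller amounts and higher numbers for an effect only at larger amounts of compound), compound 1 reaches only a limit of the assay, > 26000 nM.
Compound 2, `CCOC(=O)CCCCCOc1cccc(CN(C(=O)c2ccc(-c3cccc4ccccc34)cc2)C(C)C)c1`: in this assay compound 2 likewise stops at a limit, > 26000 nM.
Compound 3, `CCOC(=O)CCCCCOc1cccc(CN(C(=O)c2ccc(-c3cccc(-c4ccccc4)c3)cc2)C(C)C)c1`: in this assay compound 3 again gives a limit only, > 26000 nM.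

Compound 3 therefore cannot be placed on the numbers shown: every value in this assay is a limit of the same kind, as the limit of > 26000 nM in this assay, at which 3 of the 3 values shown sit, records, and no compound can be set above or below another. The two steps that end at compound 3, a step that the two limits leave unreadable from compound 1 to compound 3 and a step that the two limits leave unreadable from compound 2 to compound 3, are unreadable for the same reason, since a change between two limits has no measurable size.

Compound 4, `CCOC(=O)CCCCCOc1cccc(CN(C(=O)c2ccc(-c3cccc(OCc4ccccc4)c3)cc2)C(C)C)c1`, is not yet measured. It differs from compound 3 in one place: benzyloxy in place of phenyl on an aromatic carbon. Among the compounds with values here, no measured step covers this change; the two that exist, one exchanging the acid for its ethyl ester and one exchanging one aryl group for another, show only that the series has so far not moved off the limit. The step that the limit leaves unreadable from compound 3 to compound 4 is accordingly expected to have no readable size. Compound 4 is estimated at 30000 nM, with a range from 14000 nM to 80000 nM, and is expected most probably to be reported once more as a limit.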

Compound 4, half-maximal effective concentration: > 26000 nM
Compound 4 gave a limit, no number; the forecaster's own chance of this, stated with the estimate: 85%; the middle value does not contradict the limit.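

No size can be read for the step between compound 3 and compound 4 in this assay, since both values are limits of the same kind: the limit of > 26000 nM in this assay, at which 4 of the 4 values shown sit.

The compounds shown leave open where compound 1, compound 2, compound 3 and compound 4 would reach a half-maximal effect in this assay, and whether the ester, aryl or benzyloxy exchanges change it at all.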